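One changed stereocentre: from compound 2 to compound 4

A few compounds are considered here, and "the series" means these few. Any claim that something is new, unique, unknown or untested is made for them only; others in the source may bear on it.

Measured in a functional assay on HeLa cells (Homo sapiens) for inhibition, read by MTT assay, with a stated time of 72 h; on this read-out lower numbers stand for stronger inhibition and higher numbers for weaker inhibition:
- compound 1 `CO[C@@H]1[C@H]2OC(=O)C[C@H]2O[C@@H]1[C@@H](O)c1ccccc1`: 11000 nM
- compound 2 `CO[C@@H](c1ccccc1)[C@H]1O[C@@H]2CC(=O)O[C@@H]2[C@H]1O`: 8460 nM
- compound 3 `CO[C@@H]1[C@H]2OC(=O)C[C@H]2O[C@@H]1C(O)(c1ccccc1)c1ccccc1`: 12600 nM

Compound 2, at 8460 nM, lies within the usual scatter of both compound 1 and compound 3, so these numbers do not separate it from either one.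

The next compound to be tested is compound 4 `CO[C@H](c1ccccc1)[C@H]1O[C@@H]2CC(=O)O[C@@H]2[C@H]1O`. The structural change from compound 2 is the two compounds have the same atoms and bonds and differ only in configuration as drawn: 1 of 5 stereo elements differ; a stereocentre at a saturated chain carbon is drawn S in compound 2 and R in compound 4. The two compounds have the same atoms and bonds and differ only in configuration as drawn: a stereocentre at a saturated chain carbon is drawn S in compound 2 and R in compound 4.

Going by the values given here, no measured pair shows what a change of this kind does on its own, so the expectation is tentative and the range is wide. It rests only on how close the three measured values are. The expected result is a 1.1-fold higher number from compound 2 to compound 4 (0.05 log units; within the scatter), which means no change beyond the scatter and no direction to call. For compound 4 the estimated value is 9500 nM, with an expected range from 4000 nM to 22000 nM.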

Compound 4, half-maximal inhibitory concentration: 5640 nM
Compound 4: middle estimate off by 1.7-fold (0.23 log units), on the high side; measured number inside the range.
By their numbers in this assay, from the lowest: compounds 4, 2, 1 and 3 (each within the scatter of the next, the first and the last beyond it).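

Going by these compounds alone, this is the first pair that can be compared directly, and in this assay inverting the stereocentre at the saturated chain carbon gives a 1.5-fold lower number from compound 2 to compound 4 (0.18 log units; within the scatter). The step stays within the scatter, so at this position the drawn configuration, S or R, makes no difference that these numbers can separate, and neither form can be called the better one. Nothing else enters this comparison, since the pair is matched in every other respect: the fact that compounds 2 and 4 differ only in the configuration as drawn

The compounds shown leave open whether this lack of separation holds only for the groups now on that carbon, or whether inverting the same stereocentre would matter with an amine or a longer chain there. They also do not show what inverting any of the other stereocentres would do.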